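This account rests on a few compounds, and the source may have more. Where it says the series, first, only, none or still open, it means among the compounds named here.

Measured so far in a functional assay on the whole organism (trachea) for inhibition, with Cavia porcellus as the target; a higher number here means that more compound is needed for the effect, a lower number that less compound is needed:
- compound 1, `CCOC(=O)CC(=O)N1CCSC1COc1ccccc1OC`: compound 1 gives 11 mg/kg
- compound 2, `COc1ccccc1OCC1SCCN1C(=O)CC(C)=O`: compound 2 gives 26 mg/kg
- compound 3, `CCOC(=O)C(C)(C)C(=O)N1CCSC1COc1ccccc1OC`: compound 3 gives 48 mg/kg

For the measured compounds named here, compound 3 has the highest number of the three: the one step is a 1.8-fold higher number from compound 2 to compound 3 (0.27 log units; within the scatter), the other is a 4.4-fold higher number from compound 1 to compound 3 (0.64 log units; beyond the scatter). Compound 4, `CNC(=O)CC(=O)N1CCSC1COc1ccccc1OC`, differs from compound 3 in one place: (methylcarbamoyl)methyl in place of 1-(ethoxycarbonyl)-1-methylethyl on a carbonyl carbon. Two earlier steps bear on this. The step of a 4.4-fold higher number from compound 1 to compound 3 (0.64 log units; beyond the scatter) shows that the two extra methyls on that chain raised the number; compound 4 lacks them. The step of a 2.4-fold higher number from compound 1 to compound 2 (0.37 log units; beyond the scatter) shows that a change at the far end of the chain moved the number only modestly. A lower number is therefore expected for compound 4, by about a 3.2-fold lower number from compound 3 to compound 4 (0.51 log units; beyond the scatter). The estimate for compound 4 is 15 mg/kg, with a range from 6 mg/kg to 40 mg/kg.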

Compound 4, dose for half-maximal effect: 22 mg/kg
Beside the measured number, compound 4's estimate is 1.5-fold (0.17 log units) below it; low and high end bracket the measured number.
By their numbers in this assay, from the lowest: compounds 1, 4, 2 and 3 (each within the scatter of the next, the first and the last beyond it).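

With methylamino on the carbonyl carbon, compound 4 cannot be told apart in this assay from either neighbour (a 2.0-fold higher number from compound 1 to compound 4 (0.30 log units; within the scatter); a 1.2-fold lower number from compound 2 to compound 4 (0.07 log units; within the scatter)), so this end of the chain accepts a group carrying the amide hydrogen without a change beyond the scatter. The step to the (methylcarbamoyl)methyl group (a 2.2-fold lower number from compound 3 to compound 4 (0.34 log units; beyond the scatter)) is beyond the scatter, but it removes the two extra methyls and changes the chain end together, so it cannot be split between them. Nothing measured here explains these numbers. Still open, as far as these compounds go, is how a carboxylic acid, a dimethylamino group or a longer chain at this end would behave, and whether methylamino keeps its number with the two extra methyls present.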